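This account rests on a few compounds, and the source may have more. Where it says the series, first, only, none or still open, it means among the compounds named here.

Of the compounds shown here, three with a shared core have been measured in an ADME assay on HepG2 cells (Homo sapiens) for cytotoxicity, read by fluorescence and resazurin assay, with a stated time of 24 h; a lower number here means that less compound is tolerated, a higher number that more compound is tolerated. Compound 1 `Cc1ccc(-c2nnc(SC3=CS(=O)(=O)c4ccccc43)o2)cc1` gives 31000 nM, compound 2 `O=S1(=O)C=C(Sc2nnc(-c3ccc(Cl)cc3)o2)c2ccccc21` gives 22000 nM, and compound 3 `O=S1(=O)C=C(Sc2nnc(C3CCCCC3)o2)c2ccccc21` gives 15000 nM. Compound 3 has the lowest of the three numbers, though its gap to compound 2 is within the scatter and only its gap to compound 1 is beyond it.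

Compound 4 `O=S1(=O)C=C(Sc2nnc(-c3cccc(Cl)c3)o2)c2ccccc21` has not yet been measured. Compared with compound 3, the change is 3-chlorophenyl in place of cyclohexyl on an aromatic carbon.

Within the data shown here, two measured steps bear on this change, both running in the opposite direction, from an aromatic group to cyclohexyl: a 2.1-fold lower number from compound 1 to compound 3 (0.32 log units; beyond the scatter) and a 1.5-fold lower number from compound 2 to compound 3 (0.17 log units; within the scatter). Reversing them suggests that putting an aromatic group back in place of cyclohexyl should give a somewhat higher number, most likely of a size within the scatter, as with the step from compound 2 to compound 3. Whether a chlorine on the 3-position rather than the 4-position of the phenyl ring matters cannot be judged from these compounds.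

Compound 4 is therefore expected to lie close to compound 2, and the step is estimated as a 1.5-fold higher number from compound 3 to compound 4 (0.19 log units; within the scatter). The estimate for compound 4 in this assay is 23000 nM, within a range of 12000 nM to 45000 nM.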

Compound 4, half-maximal cytotoxic concentration: 27000 nM
Estimate against measurement, compound 4: 1.2-fold (0.07 log units) below; low and high end bracket the measured number.
By their numbers in this assay, from the lowest: compounds 3, 2, 4 and 1 (each within the scatter of the next, the first and the last beyond it).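

In this assay, among these compounds, moving the chlorine from 4-chlorophenyl to 3-chlorophenyl on this aromatic carbon gives a 1.2-fold higher number from compound 2 to compound 4 (0.09 log units; within the scatter) and so has no readable effect, a point the earlier compounds could not settle. The exchange of 4-methylphenyl for 3-chlorophenyl gives a 1.1-fold lower number from compound 1 to compound 4 (0.06 log units; within the scatter) as well, so compounds 1, 2 and 4, the three with a substituted phenyl here, cannot be told apart in this measurement. The direct exchange of cyclohexyl for 3-chlorophenyl gives a 1.8-fold higher number from compound 3 to compound 4 (0.26 log units; within the scatter) and, like the step between compound 2 and compound 3, does not clear the scatter, which leaves the step between compound 1 and compound 3 as the only contrast between a phenyl group and cyclohexyl that does.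

Going by these compounds, how an amine, a carboxylic acid or a longer chain would read at this position in this assay stays open, as does whether the cyclohexyl compound truly differs from the phenyl compounds as a group. Nothing at hand offers an explanation for any of these numbers.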